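This account rests on a few compounds, and the source may have more. Where it says the series, first, only, none or still open, it means among the compounds named here.

Working notes on the series. Compound 1 `COc1ccc([C@H]2CC(=O)N(c3ccc(C#N)cc3)C2)cc1OC1CCCC1` gives > 10000 nM in a functional assay on HEK293 cells (Homo sapiens) for cytotoxicity (a higher number here means that more compound is tolerated, a lower number that less compound is tolerated), which is a limit of the assay and not a number. Compound 2 `COc1ccc(OC)c(S(=O)(=O)Nc2cccc(N3C[C@@H](c4ccc(OC)c(OC5CCCC5)c4)CC3=O)c2)c1` holds the only number shown, and in this assay compound 2 gives 7590 nM. The other value in this assay is the limit of > 10000 nM in this assay, at which 1 of the 2 values shown sits. Compound 3 `COc1ccc([C@H]2CC(=O)N(c3cccc(NS(=O)(=O)c4c(Br)nn(C)c4Cl)c3)C2)cc1OC1CCCC1` differs from compound 2 in one place: 3-bromo-5-chloro-1-methyl-1H-pyrazol-4-yl in place of 2,5-dimethoxyphenyl on a sulfonyl sulfur. Going by the values given here, no measured step between compounds is available, so the expected step of a 1.1-fold higher number from compound 2 to compound 3 (0.02 log units; within the scatter) is set at none beyond the scatter. Compound 3 is therefore expected to give about 8000 nM, with a range of 3000 nM to 20000 nM.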

Compound 3, half-maximal cytotoxic concentration: > 10000 nM
Compound 3 was reported as a limit; the forecaster's own chance of this, stated with the estimate: 40%; at least 1.2-fold (0.09 log units) between middle value and limit.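

In this assay the step is an at least 1.3-fold higher number from compound 2 to compound 3 (0.11 log units; that floor lies within the scatter) for the change to 3-bromo-5-chloro-1-methyl-1H-pyrazol-4-yl from 2,5-dimethoxyphenyl on a sulfonyl sulfur. This shows that the 2,5-dimethoxyphenyl is not required at this position for the reading to reach the limit of the assay. The value of compound 3 is a limit and not a number, so the step gives only a floor: the limit of > 10000 nM in this assay, at which 2 of the 3 values shown sit.

As far as these compounds go, the true size of the step stays open. So does the reading in this assay of an amine or a carboxylic acid in that place.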